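The source may hold more compounds than are shown below. What is called first, only, known or untested is meant among the compounds shown, and "the series" means these compounds.

Measured compounds in an ADME assay on MT4 cells (Homo sapiens) for cytotoxicity, read by MTT assay, with a stated time of 4 days; on this read-out lower numbers stand for higher toxicity in this test and higher numbers for lower toxicity in this test:
Compound 1 `O=C1c2sccc2N(Cc2ccccc2)S(=O)(=O)N1Cc1ccccc1` gives 37500 nM.
Compound 2 `O=C1c2sccc2N(Cc2cccc(Cl)c2)S(=O)(=O)N1Cc1ccccc1` gives > 298000 nM, which is a limit of this assay rather than a number.
Compound 3 `O=C1c2sccc2N(Cc2ccc(Cl)cc2Cl)S(=O)(=O)N1Cc1ccccc1` gives 247000 nM.

Among the two numbers shown, compound 3 holds the higher one, and the step of a 6.6-fold higher number from compound 1 to compound 3 (0.82 log units; beyond the scatter) lies beyond the scatter. The step of an at least 1.2-fold lower number from compound 2 to compound 3 (0.08 log units; that floor lies within the scatter) stays within the scatter, so compound 2 and compound 3 cannot be told apart.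

Compound 4 `N#Cc1ccc(CN2c3ccsc3C(=O)N(Cc3ccccc3)S2(=O)=O)cc1` differs from compound 3 in one place: 4-cyanophenyl in place of 2,4-dichlorophenyl on a saturated chain carbon bound to a sulfonamide nitrogen in a ring. For the measured compounds named here, no measured step exchanges a chlorinated benzyl group for a cyanobenzyl group, so the only guide is that both chlorinated compounds, compound 2 and compound 3, sit well above compound 1. Whether a nitrile keeps that gain is open. Compound 4 is therefore expected to land between compound 1 and compound 3, with the step of a 2.2-fold lower number from compound 3 to compound 4 (0.35 log units; beyond the scatter) estimated as a modest fall. The estimate for compound 4 is 110000 nM, in the range 30000 nM to 300000 nM.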

Compound 4, half-maximal cytotoxic concentration: 8500 nM
Compound 4: middle estimate off by 13-fold (1.11 log units), on the high side; measured number outside the range, below it.
By their numbers in this assay, from the lowest: compound 4; then compound 1; then compound 3. At a limit, above all of these: compound 2.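

In this assay, the benzyl group on the ring sulfonamide nitrogen can shift the number in either direction: compound 2 and compound 3 rose with chlorine, but the nitrile brings a 4.4-fold lower number from compound 1 to compound 4 (0.64 log units; beyond the scatter), which makes compound 4 more toxic in this test than the unsubstituted parent. The contrast with the chlorinated compounds is larger still, with a 29-fold lower number from compound 3 to compound 4 (1.46 log units; beyond the scatter) and an at least 35-fold lower number from compound 2 to compound 4 (1.54 log units; beyond the scatter), although the groups exchanged have the same heavy-atom count. The second of these steps is only a floor, since compound 2 stands at a limit of the assay: the limit of > 298000 nM in this assay, at which 1 of the 4 values shown sits.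

On these data alone, whether the fall comes from the nitrile itself or from where it sits on the ring remains open. So does whether a different group at this position, such as a methoxy group or a carboxylic acid, would follow chlorine or the nitrile.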